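A Single Halogen Exchange on Compound 2

This account rests on a few compounds, and the source may have more. Where it says the series, first, only, none or still open, it means among the compounds named here.

Of the compounds shown here, two so far carry numbers in an ADME assay on Vero cells (Chlorocebus sabaeus) for cytotoxicity, read by resazurin assay, with a stated time of 72 h; on this read-out lower numbers stand for stronger inhibition and higher numbers for weaker inhibition. Compound 1 (`COc1ccc(C(=O)CCN2CCN(c3ccc(Cl)cc3)CC2)cc1`) gives 300000 nM. Compound 2 (`O=C(CCN1CCN(c2ccc(F)cc2)CC1)c1ccc(Br)cc1`) gives 99500 nM, the lower of the two numbers, and the gap between them lies beyond the usual scatter. Compound 3 (`O=C(CCN1CCN(c2ccc(Cl)cc2)CC1)c1ccc(Br)cc1`) has not yet been measured. It departs from compound 2 by chloro in place of fluoro on an aromatic carbon, para to a large group. No measured pair shows a change of this kind in isolation, so the data give no direct guide to its size. In this assay, a step no larger than the usual scatter is therefore expected, with no firm direction. The estimated step is a 1.2-fold lower number from compound 2 to compound 3 (0.07 log units; within the scatter). Compound 3 is expected to read 85000 nM, with an estimated range of 35000 nM to 200000 nM.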

Compound 3, half-maximal inhibitory concentration: 52100 nM
Estimate against measurement, compound 3: 1.6-fold (0.21 log units) above; measured number inside the range.
By their numbers in this assay, from the lowest: compounds 3 and 2 (each within the scatter of the next); then compound 1.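

In this assay, chloro in place of fluoro on an aromatic carbon, para to a large group, can now be read on its own, and the step is a 1.9-fold lower number from compound 2 to compound 3 (0.28 log units; within the scatter). On this evidence, the exchange from 4-fluorophenyl to 4-chlorophenyl does not separate the two compounds, although one pair cannot show how other backgrounds would respond. Bromo in place of methoxy at the other aromatic end also appears in isolation for the first time, giving a 5.8-fold lower number from compound 1 to compound 3 (0.76 log units; beyond the scatter), which lies beyond the scatter, and nothing shown accounts for either step.

As far as these compounds go, it remains open whether a nitrile or an amine in the same place as the chloro would give a step beyond the scatter. From the compounds shown here alone, it is also open whether the chloro and fluoro exchange would read the same with methoxy in place of bromo.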